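The source may hold more compounds than are shown below. What is called first, only, known or untested is meant among the compounds shown, and "the series" means these compounds.

Measured so far in an ADME assay on MCF-10A cells (Homo sapiens) for cytotoxicity, read by sulforhodamine B assay, with a stated time of 48 h; on this read-out higher numbers stand for weaker inhibition of growth and lower numbers for stronger inhibition of growth:
compound 1 `Cc1ccc2nc(/N=C3\C(=O)N(CN(C)C)c4cccc(Br)c43)sc2c1` — 21800 nM
compound 2 `CCN(CC)CN1C(=O)/C(=N\c2nc3ccc(C)cc3s2)c2c(Cl)cccc21` — 43900 nM

Both values come from this assay. Compound 2 gives the larger of the two numbers, but its gap to compound 1 lies within the usual scatter of repeated measurements, so the two compounds cannot be told apart on these data. Going by the values given here, compound 1 and compound 2 differ in more than one place, so no single step between them can be read from the pair.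

Compound 3 `Cc1ccc2nc(/N=C3\C(=O)N(CN(C)C)c4cccc(Cl)c43)sc2c1` is not yet measured. It differs from compound 2 by dimethylamino in place of diethylamino on a saturated chain carbon bound to an amide-type nitrogen in a ring; in the part that changes, compound 3 matches compound 1, while it keeps the rest of compound 2. Among the compounds with values here, no measured pair covers this change on its own. With the two measured values sitting close together, the expected step from compound 2 to compound 3 in this assay is small, without a preferred direction and not beyond the scatter, estimated as a 1.5-fold lower number from compound 2 to compound 3 (0.17 log units; within the scatter). For compound 3 the estimated value in this assay is 30000 nM, with an expected range from 12000 nM to 75000 nM.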

Compound 3, concentration for 50% growth inhibition: 7020 nM
The estimate for compound 3 lay 4.3-fold (0.63 log units) above the measured number; the whole stated range lies above it.
By their numbers in this assay, from the lowest: compound 3; then compounds 1 and 2 (each within the scatter of the next).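

In this assay, dimethylamino in place of diethylamino on a saturated chain carbon bound to an amide-type nitrogen in a ring gives a 6.3-fold lower number from compound 2 to compound 3 (0.80 log units; beyond the scatter) and so shows that the read-out responds to this change alone, which the earlier pair, differing in more than one place, could not show. With the dimethylamino group held fixed, chloro in place of bromo on an aromatic carbon gives a 3.1-fold lower number from compound 1 to compound 3 (0.49 log units; beyond the scatter) and shows that this second place also moves the number, so the close values of the earlier pair do not mean that either place is without effect. Nothing measured here bears on the reason for either step.

Open, going by these compounds, is whether the dimethylamino step holds with bromo on the aromatic carbon and whether the chloro step holds with diethylamino on the chain, since each step is read against one background only. Also open, on these data alone, is how this assay reads a ring amine such as morpholine in place of dimethylamino, or fluoro in place of chloro.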